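This account rests on a few compounds, and the source may have more. Where it says the series, first, only, none or still open, it means among the compounds named here.

Measured so far in a functional assay on MCF7 cells (Homo sapiens) for inhibition, read by MTT assay; a lower number here means a stronger inhibitor, a higher number a weaker inhibitor:

Compound 1, `COc1cc2ncnc(Nc3ccc(NC(=O)c4ccccc4F)cc3)c2cc1OC`: 11000 nM
Compound 2, `COc1cc2ncnc(Nc3ccc(NC(=O)c4ccc(Br)cc4)cc3)c2cc1OC`: 43000 nM

Among these two numbers, compound 1 gives the lowest, so within this small set it is the stronger inhibitor of the pair, its nearest neighbour being compound 2 at a 3.9-fold higher number from compound 1 to compound 2 (0.59 log units; beyond the scatter). For the measured compounds named here, that single step, which swapped the whole ring attached to the carbonyl, is the only measured change available, and it does not alter the same spot as the change now considered.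

The unmeasured compound 3, `COc1cc2ncnc(Nc3ccc(NC(=O)c4c(F)cccc4F)cc3)c2cc1OC`, differs from compound 1 by fluoro in place of hydrogen on an aromatic carbon. Nothing measured tests adding a second fluoro on that ring; the step from compound 1 to compound 2 only shows that moving away from the 2-fluorophenyl arrangement weakened inhibition by a modest amount. With the fluoro kept and a second one added, no shift beyond the scatter is expected, with perhaps a slight lean toward a lower number.

Compound 3 is therefore estimated at 9000 nM in this assay, with a range of 3500 nM to 25000 nM, a step of a 1.2-fold lower number from compound 1 to compound 3 (0.09 log units; within the scatter).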

Compound 3, half-maximal inhibitory concentration: 24000 nM
Compound 3: middle estimate off by 2.7-fold (0.43 log units), on the low side, and the stated range covers the measured number.
By their numbers in this assay, from the lowest: compound 1; then compounds 3 and 2 (each within the scatter of the next).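

In this assay, adding a second fluoro to the ring on the carbonyl, which turns 2-fluorophenyl into 2,6-difluorophenyl, gives a 2.2-fold higher number from compound 1 to compound 3 (0.34 log units; beyond the scatter), so this position responds to a change of a single heavy atom, and here the response is toward weaker inhibition. Replacing the 4-bromophenyl group with 2,6-difluorophenyl gives a 1.8-fold lower number from compound 2 to compound 3 (0.25 log units; within the scatter), so these two quite different rings cannot be told apart in this assay, while the 2-fluorophenyl ring of compound 1 keeps the lowest number of the three, beyond the scatter of both others. Nothing at hand accounts for the effect of the added fluoro.

The compounds shown leave open whether the loss is particular to fluoro or would also follow from another group at the same position, such as chloro, methyl, methoxy or an amine. They also leave open how a plain phenyl ring with no fluoro at all would compare, which would show whether the first fluoro of compound 1 helps, harms or makes no difference.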